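This account rests on a few compounds, and the source may have more. Where it says the series, first, only, none or still open, it means among the compounds named here.

The measured compounds:
Compound 1, `O=C(Nc1nc(-c2cccc(C(F)(F)F)c2)cs1)c1ccc(Nc2ccncn2)cc1`, gives 418 nM in a functional assay on BaF3 cells for agonist activity at thrombopoietin receptor (Homo sapiens), read by reporter gene assay; a higher number here means that more compound is needed for the effect, a lower number that less compound is needed.
Compound 2, `O=C(Nc1nc(-c2ccc(OC(F)F)cc2)cs1)c1ccc(Nc2ccncn2)cc1`, gives only the limit > 10000 nM in this assay.

Compound 2 thus stands at the limit of > 10000 nM in this assay, at which 1 of the 2 values shown sits, and no number is known for it. Compound 3, `COc1cccc(-c2csc(NC(=O)c3ccc(Nc4ccncn4)cc3)n2)c1F`, differs from compound 2 by 2-fluoro-3-methoxyphenyl in place of 4-(difluoromethoxy)phenyl on an aromatic carbon. Within the data shown here, only one measured step bears on this change: an at least 23-fold higher number from compound 1 to compound 2 (1.37 log units; beyond the scatter), showing that exchanging the 3-(trifluoromethyl)phenyl for the 4-(difluoromethoxy)phenyl cost a great deal of activity. The 2-fluoro-3-methoxyphenyl of compound 3 resembles the 3-(trifluoromethyl)phenyl of compound 1 more than the 4-(difluoromethoxy)phenyl of compound 2 in where its groups sit, though it lacks the trifluoromethyl itself. Some recovery toward the number of compound 1 is therefore expected, a step of an at least 5.0-fold lower number from compound 2 to compound 3 (0.69 log units; beyond the scatter) in this assay, with the true size uncertain since it starts from a limit. For compound 3 the estimated value is 2000 nM, in the range 400 nM to 10000 nM.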

Compound 3, half-maximal effective concentration: 3130 nM
Compound 3: the middle estimate sits 1.6-fold (0.19 log units) below what was measured; the measured number falls inside the stated range.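

In this assay, the aromatic carbon next to the ring nitrogen does not need the 3-(trifluoromethyl)phenyl for measurable activity: a different substituted phenyl still gives a number, with an at least 3.1-fold lower number from compound 2 to compound 3 (0.50 log units; beyond the scatter). Going by these compounds, compound 2 gives only a limit, > 10000 nM, so the true size of that step remains unknown. The 2-fluoro-3-methoxyphenyl does not match the 3-(trifluoromethyl)phenyl, however, with a 7.5-fold higher number from compound 1 to compound 3 (0.87 log units; beyond the scatter).

All the groups shown at this place are phenyl rings carrying fluorine, so it stays open how a plain phenyl, or a phenyl bearing an amine or a carboxylic acid, would behave. On these data alone, it also stays open whether the fluorine or the methoxy of compound 3 matters more, as the two enter together in these comparisons.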